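This account rests on a few compounds, and the source may have more. Where it says the series, first, only, none or still open, it means among the compounds named here.

Working notes on the series. Compound 1 `CC(O)n1cnc2c(N)nc(I)nc21` gives in a functional assay on L1210 cells (Mus musculus) for inhibition (on this read-out lower numbers stand for stronger inhibition and higher numbers for weaker inhibition), a value of 490000 nM; compound 2 `CC(=O)OC(C)n1cnc2c(N)nc(I)nc21` gives 421000 nM in this assay. The change from compound 2 to compound 1, (hydrogen in place of acetyl on an oxygen on a saturated carbon), made a step of a 1.2-fold higher number from compound 2 to compound 1 (0.07 log units; within the scatter). Compound 3 `CC(=O)OC(C)n1cnc2c(S)nc(F)nc21` carries a different core; the difference between the two cores is not broken down here. In this assay compound 3 gives 226000 nM, the lowest of the three numbers, within the scatter of compound 2 and beyond it only against compound 1.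

Compound 4 `CC(O)n1cnc2c(S)nc(F)nc21` is not yet measured. From compound 3 it differs by hydrogen in place of acetyl on an oxygen on a saturated carbon, the same change as that from compound 2 to compound 1, with the place described in the same words. A step of like size is expected, resting on the earlier step of a 1.2-fold higher number from compound 2 to compound 1 (0.07 log units; within the scatter) in this assay, namely a 1.2-fold higher number from compound 3 to compound 4 (0.08 log units; within the scatter). For compound 4 the estimated value in this assay is 270000 nM, with an expected range from 130000 nM to 560000 nM.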

Compound 4, half-maximal inhibitory concentration: > 500000 nM
Compound 4 was reported as a limit; the forecaster's own chance of this, stated with the estimate: 5%; at least 1.8-fold (0.26 log units) between middle value and limit.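

Hydrogen in place of acetyl on an oxygen on a saturated carbon gives an at least 2.2-fold higher number from compound 3 to compound 4 (0.34 log units; beyond the scatter) on the core of compound 3, so the step there lies beyond the scatter in this assay while the earlier step does not. On these data alone, for compound 4 the assay gives only a limit, > 500000 nM and no number, so the full size of this step remains unknown. The data therefore neither show that the change carries over from one core to the other nor show that it fails to: the same change on two cores in this assay, a 1.2-fold higher number (0.07 log units; within the scatter) from compound 2 to compound 1 and an at least 2.2-fold higher number (0.34 log units; beyond the scatter) from compound 3 to compound 4; the limit leaves it open whether they differ

Open, as far as these compounds go, is how a longer acyl chain such as butyryl, or an amine in place of the hydroxy, would read in this assay on either core. Also open, from the compounds shown here alone, is whether a third core would repeat either step.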